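This account rests on a few compounds, and the source may have more. Where it says the series, first, only, none or still open, it means among the compounds named here.

Measured so far:
Compound 1 `O=C(Nc1ccc(F)cc1F)c1cc(=O)[nH]c2cc(Br)ccc12`: > 20000 nM, a limit of the assay.
Compound 2 `O=C(Nc1ccc(F)cc1)c1cc(=O)[nH]c2cc(Br)ccc12`: > 20000 nM, a limit of the assay.
Compound 3 `O=C(Nc1cc(F)c(F)c(F)c1)c1cc(=O)[nH]c2cc(Br)ccc12`: > 20000 nM, a limit of the assay.

All three values come from a functional assay on KYSE-70 cells for antiproliferative activity against KYSE-70 cell line (Homo sapiens), read by MTT assay, with a stated time of 72 h; a lower number here means a stronger inhibitor, a higher number a weaker inhibitor. Compound 4 `O=C(Nc1cc(F)cc(F)c1)c1cc(=O)[nH]c2cc(Br)ccc12` has not yet been measured in this assay.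

The change from compound 1 to compound 2 is hydrogen in place of fluoro on an aromatic carbon. Its step, a step that the two limits leave unreadable from compound 1 to compound 2, cannot be sized because of the limit of > 20000 nM in this assay, at which 3 of the 3 values shown sit. The change from compound 3 to compound 4 is hydrogen in place of fluoro on an aromatic carbon. It is the same kind of change, but the surroundings of the place differ: in compound 1 the carbon carrying the fluoro is ortho to a large group and meta to a fluoro group, whereas in compound 3 it is ortho to two fluoro groups and para to a large group. How the cores of compound 3 and compound 1 differ is not broken down here.

For compound 4, the expected step is a step that the limit leaves unreadable from compound 3 to compound 4, resting only on (the limit of > 20000 nM in this assay, at which 3 of the 3 values shown sit). Compound 4 is estimated at 30000 nM in this assay, most likely reported again as a limit, with a range from 10000 nM to 100000 nM.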

Compound 4, half-maximal inhibitory concentration: 10700 nM
For compound 4 the middle estimate is 2.8-fold (0.45 log units) above the measured one; the measured number falls inside the stated range.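

In this assay, hydrogen in place of fluoro on an aromatic carbon gives an at least 1.8-fold lower number from compound 3 to compound 4 (0.27 log units; that floor lies within the scatter), so this is only a floor on the step; the carbon involved is ortho to two fluoro groups and para to a large group. This shows that compound 4 gives a measurable value where compound 3 does not, but it does not show a real gain from the change. Whether the change carries over from one setting to another cannot be judged, since the same replacement from compound 1 to compound 2 cannot be read, because both values are limits: the limit of > 20000 nM in this assay, at which 3 of the 4 values shown sit.

Still open, as far as these compounds go, is how far the true step from compound 3 to compound 4 exceeds that floor, as the value of compound 3 is only a limit. Also open, from the compounds shown here alone, is how this assay would read with an amine or a carboxylic acid on that aromatic ring in place of fluoro.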